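The compounds below may be only part of what the source reports. "The series", "measured", "known", "first", "only" and "open" are said of these compounds alone.

In a physicochemical assay for lipophilicity, read by HPLC, measured as chromatographic lipophilicity, at pH 7.4 (a lower number here means a more polar compound, a higher number a more lipophilic compound), compound 2 `COc1cccc(NC(=O)c2nnn(Cc3ccc(C(C)C)cc3)c2N)c1` stands highest of the three measured compounds at 3.4, with compound 3 `COc1cccc(NC(=O)c2nnn(Cc3cc(C)on3)c2N)c1` at 2 and compound 1 `COc1cccc(NC(=O)c2nnn(CC3CCN(C(C)=O)CC3)c2N)c1` at 1.2. Compound 4 `COc1cccc(NC(=O)c2nnn(Cc3ccc(-n4cccn4)cc3)c2N)c1` differs from compound 2 by a single change: 1H-pyrazol-1-yl in place of isopropyl on an aromatic carbon. Among the compounds with values here, no measured step makes this exact change. The closest guide is the large a number 1.40 log units lower from compound 2 to compound 3 (beyond the scatter), where 5-methyl-1,2-oxazol-3-yl replaces 4-isopropylphenyl. The large a number 2.20 log units higher from compound 1 to compound 2 (beyond the scatter) and the modest a number 0.80 log units higher from compound 1 to compound 3 (beyond the scatter) also exchange the whole group. Compound 4 keeps the six-membered aromatic ring of carbon only, so a modest fall, smaller than the closest guide, is expected in this assay. The expected change is a number 0.50 log units lower from compound 2 to compound 4 (beyond the scatter). Compound 4 is estimated at 2.9, with an expected range of 2.5 to 3.3.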

Compound 4, distribution coefficient: 2.4
The estimate for compound 4 lay 0.50 log units above the measured number; the whole stated range lies above it.
By their numbers in this assay, from the lowest: compound 1; then compound 3; then compound 4; then compound 2.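

In this assay, within the data shown here, the earlier steps exchanged the whole group on the saturated chain carbon, whereas this change keeps the six-membered aromatic ring of carbon only. The step of a number 1.00 log units lower from compound 2 to compound 4 (beyond the scatter) shows that replacing isopropyl with 1H-pyrazol-1-yl at this one position, para to a large group, is enough to move the number beyond the scatter. Nothing measured here explains the size of this step.

The compounds shown leave open how a phenyl ring, a morpholine or a carboxylic acid would read on this same aromatic carbon.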